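A few compounds are considered here, and "the series" means these few. Any claim that something is new, unique, unknown or untested is made for them only; others in the source may bear on it.

Among the measured compounds shown here, compound 2 `N#Cc1c(N2CCC(c3ccccc3Cl)CC2)ccn(CC2CC2)c1=O` is one of two compounds so far measured in a functional assay on CHO cells for positive allosteric modulation of metabotropic glutamate receptor 2 (Homo sapiens), with a stated time of 30 min (on this read-out lower numbers stand for smaller maximal responses and higher numbers for larger maximal responses), where compound 2 gives 259%. Compound 1 `N#Cc1c(N2CCC(c3ccc(F)cc3)CC2)ccn(CC2CC2)c1=O` gives 258% in this assay, and the two numbers lie within the usual scatter of each other. For the measured compounds named here, the only measured step at the saturated ring carbon, 2-chlorophenyl in place of 4-fluorophenyl, is a number 1 percentage points higher from compound 1 to compound 2 (within the scatter). Compound 3 `COc1ccc(C2CCN(c3ccn(CC4CC4)c(=O)c3C#N)CC2)cc1` carries a further change at the same place: 4-methoxyphenyl in place of 2-chlorophenyl on a saturated ring carbon. Going by the values given here, the one step that bears on this position is the one just described, and it did not move the maximal response beyond the scatter, so no step beyond the scatter is expected for the new aryl group either. Compound 3 is estimated to give 258% in this assay, with a range from 235% to 280%, and the expected step of a number 1 percentage points lower from compound 2 to compound 3 (within the scatter) is judged to stay within the scatter.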

Compound 3, largest response reached (Emax), in percent of the reference or control that the assay uses: 257%
Compound 3: middle estimate off by 1 percentage points, on the high side, within the range that was stated.
By their numbers in this assay, from the lowest: compounds 3, 1 and 2 (each within the scatter of the next).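

The new compound adds a second kind of change at this position: with the aryl group kept, a substituent with an oxygen takes the place of a halogen. The step of 4-methoxyphenyl in place of 2-chlorophenyl on the saturated ring carbon is a number 2 percentage points lower from compound 2 to compound 3 (within the scatter) in this assay and brings in a hydrogen-bond acceptor where the leaving group counts none, while methoxy in place of fluoro on an aromatic carbon gives a number 1 percentage points lower from compound 1 to compound 3 (within the scatter) as its direct comparison. Nothing measured explains why the maximal response stays level across these groups.

Among the compounds shown here, all three compounds carry a substituted phenyl ring on the saturated ring carbon, so this flat picture covers only that kind of group. From the compounds shown here alone, whether an amine or a carboxylic acid on that phenyl ring, or a longer alkyl chain in its place, would shift the maximal response remains open.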